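The compounds below may be only part of what the source reports. "The series", "measured", "known", "first", "only" and "open" are said of these compounds alone.

Compound 1 `COc1ccc(Cl)cc1S(=O)(=O)Nc1ccc2oc(-c3ccccc3)nc2c1` and compound 2 `O=S(=O)(Nc1ccc2oc(-c3ccccc3)nc2c1)c1ccc(Cl)c(Cl)c1` share one core; compound 3 `COc1ccc(Cl)cc1S(=O)(=O)Nc1ccc(-c2nc3ccccc3o2)cc1` and compound 4 `O=S(=O)(Nc1ccc(-c2nc3ccccc3o2)cc1)c1ccc(Cl)c(Cl)c1` share the other, and the difference between the two cores is not broken down here. In an assay on cells for inhibition of HSP60/HSP10 (Homo sapiens), with a stated time of 60 min (a higher number here means a weaker inhibitor, a lower number a stronger inhibitor), compound 1 gives only a limit, > 100000 nM. Compound 2 likewise reaches only the limit of this assay, > 100000 nM. The change from compound 1 to compound 2 is 3,4-dichlorophenyl in place of 5-chloro-2-methoxyphenyl on a sulfonyl sulfur and it made a step that the two limits leave unreadable from compound 1 to compound 2, unreadable because of the limit of > 100000 nM in this assay, at which 3 of the 3 values shown sit. Compound 3 too stops at the limit of this assay, > 100000 nM. From compound 3 to compound 4 the same change is made, (3,4-dichlorophenyl in place of 5-chloro-2-methoxyphenyl on a sulfonyl sulfur), at an identical place. The expected step is a step that the limit leaves unreadable from compound 3 to compound 4, resting on a step that the two limits leave unreadable from compound 1 to compound 2. Compound 4 is estimated at 150000 nM, most likely again only as a limit of this assay, within 50000 nM to 500000 nM.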

Compound 4, half-maximal inhibitory concentration: 25000 nM
Estimate against measurement, compound 4: 6.0-fold (0.78 log units) above; measured number below the stated range.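

In this assay, as far as these compounds go, 3,4-dichlorophenyl in place of 5-chloro-2-methoxyphenyl on a sulfonyl sulfur gives an at least 4.0-fold lower number from compound 3 to compound 4 (0.60 log units; beyond the scatter), and the true size of this step stays open, since it starts from a limit. On the other core, compound 2 remains at a limit, > 100000 nM. The same change therefore shows a gain on the core of compound 3 but neither a gain nor a loss on the core of compound 1, and the steps that end at a limit cannot be read, so carry-over between the cores remains untested, because of the assay ceiling: the limit of > 100000 nM in this assay, at which 3 of the 4 values shown sit.

The compounds shown leave open which part of the exchange matters, as methoxy and chlorine differ together. Also open, from the compounds shown here alone, is how a plain phenyl, a carboxylic acid or an amine would behave on the sulfonyl sulfur.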